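The source may report more compounds than this note shows. Statements on the series, on what has been measured and on what is new or still open speak of the compounds shown alone.

Measured so far in an assay on cells for inhibition of Ectonucleotide pyrophosphatase/phosphodiesterase family member 1 (Homo sapiens), with a stated time of 60 min, tested at 1 uM; a lower number here means less inhibition, a higher number more inhibition at the concentration tested (going by the name of the read-out):
compound 1 `COc1cc2nc(/C=C/c3ccccc3)nc(N3CCC(CCNS(N)(=O)=O)CC3)c2cc1OC` gives 33%;
compound 2 `COc1cc2nc(/C=C/c3ccccn3)nc(N3CCC(CCNS(N)(=O)=O)CC3)c2cc1OC` gives 85%;
compound 3 `COc1cc2nc(/C=C/c3ccncc3)nc(N3CCC(CCNS(N)(=O)=O)CC3)c2cc1OC` gives 79%.

Compound 3 holds the second highest of the three numbers in this assay. Its nearest neighbour is compound 2, where the step of a number 6 percentage points lower from compound 2 to compound 3 (within the scatter) stays within the scatter; the distance to compound 1 is large, as the step of a number 46 percentage points higher from compound 1 to compound 3 (beyond the scatter) shows.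

Compound 4 `COc1cc2nc(/C=C/c3ccccc3F)nc(N3CCC(CCNS(N)(=O)=O)CC3)c2cc1OC` is the next step from compound 3. The change is 2-fluorophenyl in place of pyridin-4-yl on a double-bonded chain carbon bound to a double-bonded chain carbon. The new group is a six-membered aromatic ring of carbon only carrying fluorine; the hydrogen-bond acceptor of the pyridin-4-yl is gone.

Within the data shown here, the step that bears on this is the one from compound 1, whose ring is also a carbon-only phenyl, to compound 3: a number 46 percentage points higher from compound 1 to compound 3 (beyond the scatter). The step of a number 52 percentage points higher from compound 1 to compound 2 (beyond the scatter) points the same way. Reversing that change is therefore expected to cost a large part of the inhibition. Among the measured compounds shown here, the fluorine has no measured counterpart, so its own effect is unknown.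

For compound 4 the expected step is a number 41 percentage points lower from compound 3 to compound 4 (beyond the scatter), a drop beyond the scatter. Compound 4 is thus estimated at 38%, within 15% to 65%.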

Compound 4, a percentage reported as inhibition, at one concentration (the size of the read-out at that concentration, not a potency): 78%
For compound 4 the middle estimate is 40 percentage points below the measured one; measured number outside the range, above it.
By their numbers in this assay, from the lowest: compound 1; then compounds 4, 3 and 2 (each within the scatter of the next).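

In this assay, a hydrogen-bond acceptor on the ring at this place is not required for high inhibition: 2-fluorophenyl has none, yet the step of a number 1 percentage points lower from compound 3 to compound 4 (within the scatter) and the step of a number 7 percentage points lower from compound 2 to compound 4 (within the scatter) leave it level with both pyridine compounds. Among these compounds, the carbon-only ring is thus not poor in itself, since the single change of fluoro in place of hydrogen on an aromatic carbon gives the step of a number 45 percentage points higher from compound 1 to compound 4 (beyond the scatter) and recovers what the pyridines showed over phenyl. No measurement shown explains why fluoro and the pyridine nitrogen end up level.

From the compounds shown here alone, whether this gain is specific to fluoro remains open, as chloro or methoxy in its place would test that. Also open, going by these compounds, is whether fluoro on a pyridin-2-yl ring would add anything to the inhibition.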